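Acrylamide aryl swap in a quinoline amide series

A few compounds are considered here, and "the series" means these few. Any claim that something is new, unique, unknown or untested is made for them only; others in the source may bear on it.

Three compounds on a shared core have numbers in an assay on isolated protein for displacement of a labelled ligand from melanin-concentrating hormone receptor 1 (Homo sapiens); on this read-out lower numbers stand for stronger inhibition and higher numbers for weaker inhibition. Compound 1 `CCCc1cc(N)c2cc(NC(=O)/C=C/c3ccc(N)cc3)ccc2n1` gives 190 nM, the highest of the three. Compound 2 `CCCc1cc(N2CCCC2)c2cc(NC(=O)/C=C/c3ccc(C(F)(F)F)cc3)ccc2n1` gives 17 nM, which stands well below compound 1, and compound 3 `CCCc1cc(N)c2cc(NC(=O)c3ccc(-c4ccc(Cl)cc4)cc3)ccc2n1` gives 0.7 nM, the lowest of the set by a wide margin; both gaps to compound 1 lie beyond the scatter, but both compounds differ from compound 1 in more than one place, so no single step is shown.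

Compound 4 `CCCc1cc(N)c2cc(NC(=O)/C=C/c3cccc(Cl)c3)ccc2n1` is not yet measured. It keeps the primary amine on the core and the double-bonded chain of compound 1 and changes only the aryl on that chain: 3-chlorophenyl in place of 4-aminophenyl on a double-bonded chain carbon bound to a double-bonded chain carbon. Going by the values given here, no measured pair isolates this change. The expectation is a step from compound 1 to compound 4 towards a lower number, a 4.8-fold lower number from compound 1 to compound 4 (0.68 log units; beyond the scatter), because compound 2, which also carries a halogen-bearing phenyl on the chain, gives 17 nM. Compound 4 is therefore estimated at 40 nM, with a range from 10 nM to 150 nM.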

Compound 4, half-maximal inhibitory concentration: 1100 nM
Estimate against measurement, compound 4: 28-fold (1.44 log units) below, and the stated range ends below it.
By their numbers in this assay, from the lowest: compound 3; then compound 2; then compound 1; then compound 4.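

In this assay, the series now has its first step that changes one place only: 3-chlorophenyl in place of 4-aminophenyl on a double-bonded chain carbon bound to a double-bonded chain carbon gives a 5.8-fold higher number from compound 1 to compound 4 (0.76 log units; beyond the scatter), so the number at this position does respond to the aryl, and here the chlorine-bearing ring is the weaker of the two. The step swaps a ring with 1 hydrogen-bond donor and 1 hydrogen-bond acceptor for one with 0 of each, and it moves the substituent as well as changing it. No measurement available here gives a reason for the step.

Open, going by these compounds, is whether the change of substituent or the change of its place carries the step, which a 3-aminophenyl on the same chain would help to separate. Also open, on these data alone, is whether the same swap gives a similar step with the pyrrolidine of compound 2 on the core.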